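This account rests on a few compounds, and the source may have more. Where it says the series, first, only, none or still open, it means among the compounds named here.

Compounds measured so far:

Compound 1, `CC(=O)c1ccc(NC(=O)Nc2cc(C)nc3ccccc23)cc1` — 3800 nM
Compound 2, `Cc1cc(NC(=O)Nc2ccccc2C(C)(C)C)c2ccccc2n1` — 100 nM
Compound 3, `Cc1cc(NC(=O)Nc2ccccc2C(F)(F)F)c2ccccc2n1` — 3800 nM

The read-out throughout is a physicochemical assay for solubility, at pH 7.4; on this read-out higher numbers stand for higher solubility and lower numbers for lower solubility. Compound 1 gives 3800 nM, which at the digits shown is level with compound 3 at 3800 nM; together these two are the highest of the three numbers, and the gap between them lies within the scatter. Compound 2, at 100 nM, sits far below compound 1. Among the measured compounds shown here, the one step in this set that joins two compounds differing in a single place is a 38-fold higher number from compound 2 to compound 3 (1.58 log units; beyond the scatter), a large step, but it concerns a different pair of groups at a different position.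

The compound now in question is compound 4, `COc1ccc(NC(=O)Nc2cc(C)nc3ccccc23)cc1`. It differs from compound 1 in one place: methoxy in place of acetyl on an aromatic carbon. For the measured compounds named here, no measured step exchanges acetyl for methoxy, so nothing here speaks directly to the size or direction of the change. The replacement is small in counted atoms and leaves the acceptor count unchanged, and the expectation is therefore a step of a 1.1-fold lower number from compound 1 to compound 4 (0.04 log units; within the scatter), not beyond the scatter in either direction. For compound 4 the estimated value in this assay is 3500 nM, with a range from 1200 nM to 10000 nM.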

Compound 4, solubility: 19800 nM
The estimate for compound 4 lay 5.7-fold (0.75 log units) below the measured number; measured number outside the range, above it.
By their numbers in this assay, from the lowest: compound 2; then compounds 1 and 3 (each within the scatter of the next); then compound 4.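

In this assay, the place on the aromatic carbon of the six-membered aromatic ring of carbon only, para to a large group, now has a measured step of its own: methoxy in place of acetyl gives a 5.2-fold higher number from compound 1 to compound 4 (0.72 log units; beyond the scatter). Among the compounds shown here, the earlier compounds offered no reading here, as their one single-place step, a 38-fold higher number from compound 2 to compound 3 (1.58 log units; beyond the scatter), concerned trifluoromethyl in place of tert-butyl at another place, so this is the first sign that the number responds to a change at this position, and that it does so even though the count of hydrogen-bond acceptors stays the same and the two groups differ little in heavy atoms. Nothing in the available evidence accounts for the step, which therefore stands as an observation only.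

The compounds shown leave open whether the step follows from the arrival of methoxy or from the departure of acetyl, a question that a plain hydrogen, a fluorine or an ethoxy at the same carbon would bear on. They also leave open how an amine or a carboxylic acid at this place would read, and whether methoxy would give a similar step with the other groups in this series.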